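Hexahydroquinolinone esters: lipophilicity notes, methoxy to cyano

The source may report more compounds than this note shows. Statements on the series, on what has been measured and on what is new or still open speak of the compounds shown alone.

Measured so far:
compound 1 `COc1ccc(C2C(C(=O)OCc3ccccn3)=C(C)NC3=C2C(=O)CCC3)cc1`: 1.9
compound 2 `CC1=C(C(=O)OCc2cccnc2)C(c2cccc(O)c2)C2=C(CCCC2=O)N1`: 1.21
compound 3 `COc1ccc(C2C(C(=O)OCc3cccnc3)=C(C)NC3=C2C(=O)CCC3)cc1`: 1.54

All three numbers come from a physicochemical assay for lipophilicity, measured as octanol-water partition; on this read-out lower numbers stand for lower lipophilicity and higher numbers for higher lipophilicity. Compound 1 stands highest of the three; its nearest neighbour is compound 3, and the step of a number 0.36 log units lower from compound 1 to compound 3 (beyond the scatter) separates them, while compound 2 lies furthest below. The second measured step, a number 0.33 log units higher from compound 2 to compound 3 (beyond the scatter), shows that exchanging the group on the saturated ring carbon, 3-hydroxyphenyl for 4-methoxyphenyl, also moves this assay by a modest amount.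

Compound 4 `CC1=C(C(=O)OCc2ccccn2)C(c2ccc(C#N)cc2)C2=C(CCCC2=O)N1` is not yet measured. It differs from compound 1 in one place: cyano in place of methoxy on an aromatic carbon. Among the compounds with values here, no measured pair covers this exact exchange; the closest guide is the step from compound 2 to compound 3, where the change on the same aryl ring gave a modest step. A modest step is therefore expected here as well, and compound 4 is expected to come out somewhat lower than compound 1, by about a number 0.50 log units lower from compound 1 to compound 4 (beyond the scatter). The estimate for compound 4 in this assay is 1.4, with a range from 1 to 1.8.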

Compound 4, partition coefficient: 1.73
The estimate for compound 4 lay 0.33 log units below the measured number; the range from low to high includes it.
By their numbers in this assay, from the lowest: compound 2; then compounds 3, 4 and 1 (each within the scatter of the next, the first and the last beyond it).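

In this assay, cyano in place of methoxy on an aromatic carbon, para to a large group, gives a number 0.17 log units lower from compound 1 to compound 4 (within the scatter), so this read-out does not separate compound 1 from compound 4. On the same aryl ring, the exchange of 3-hydroxyphenyl for 4-methoxyphenyl gave a number 0.33 log units higher from compound 2 to compound 3 (beyond the scatter), which lies beyond the scatter, so not every exchange on this ring stays within it. No measurement at hand accounts for either result.

Within the data shown here, whether 4-methoxyphenyl to 4-cyanophenyl reads the same with the pyridin-3-yl ester of compound 3 remains open, as the only pair for this exchange carries the pyridin-2-yl ester. Also open, from the compounds shown here alone, is how this position responds to groups of another kind, such as an amine, a carboxylic acid or a longer chain.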